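Cytotoxicity notes on the shared core, third analogue

The compounds below may be only part of what the source reports. "The series", "measured", "known", "first", "only" and "open" are said of these compounds alone.

Compound 1 `CCc1cn(COCCO)c(=S)[nH]c1=O` in a functional assay on Vero cells (Chlorocebus sabaeus) for cytotoxicity, read by MTT assay (a lower number here means that less compound is tolerated, a higher number that more compound is tolerated), gives > 478000 nM, a limit of the assay.
Compound 2 `O=c1ccn(COCCO)c(=S)[nH]1` in this assay gives > 495000 nM, also a limit.

Compound 2 therefore stands only at a limit in this assay. Among the measured compounds shown here, the one measured step, a step that the two limits leave unreadable from compound 1 to compound 2, cannot be read in size; the limit of > 478000 nM in this assay, at which 1 of the 2 values shown sits, and the limit of > 495000 nM in this assay, at which 1 of the 2 values shown sits, both cap the readings. Compound 3 `CCOC(=O)c1cn(COCCO)c(=S)[nH]c1=O` differs from compound 2 by ethoxycarbonyl in place of hydrogen on an aromatic carbon. For the measured compounds named here, no measured step resolves this change, so no step beyond the scatter is expected in this assay; the expected step is an at least 1.0-fold lower number from compound 2 to compound 3 (0.01 log units; that floor lies within the scatter). Compound 3 is estimated at 480000 nM, within 200000 nM to 1000000 nM, most likely again reported as a limit.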

Compound 3, half-maximal cytotoxic concentration: > 364000 nM
Compound 3 gave a limit, no number; the forecaster's own chance of this, stated with the estimate: 80%; the middle value is on the limit's open side.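

Among the compounds shown here, compound 1, compound 2 and compound 3 all stand only at limits in this assay, so no step among them can be read. On these data alone, the concentration at which any of them turns cytotoxic remains open.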